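The source may hold more compounds than are shown below. What is called first, only, known or untested is meant among the compounds shown, and "the series" means these compounds.

Compounds measured so far:
compound 1 `CC(C)=CC[C@@H](OC(=O)C1CCOC1)C1=CC(=O)c2c(O)ccc(O)c2C1=O` — 73500 nM
compound 2 `CCC(O)(CC)CC(=O)O[C@H](CC=C(C)C)C1=CC(=O)c2c(O)ccc(O)c2C1=O` — 52000 nM
compound 3 `CC(C)=CC[C@@H](OCCO)C1=CC(=O)c2c(O)ccc(O)c2C1=O` — 18600 nM

In a functional assay on HeLa cells (Homo sapiens) for cytotoxicity, read by MTT assay (on this read-out higher numbers stand for weaker inhibition and lower numbers for stronger inhibition), compound 1 gives the highest of the three numbers; its nearest neighbour is compound 2, with a 1.4-fold lower number from compound 1 to compound 2 (0.15 log units; within the scatter), and its furthest is compound 3, with a 4.0-fold lower number from compound 1 to compound 3 (0.60 log units; beyond the scatter). Compound 2 and compound 3 are themselves separated by a 2.8-fold lower number from compound 2 to compound 3 (0.45 log units; beyond the scatter). Compound 4 `CC(C)=CC[C@@H](OC(=O)C1CCCOC1)C1=CC(=O)c2c(O)ccc(O)c2C1=O` has not yet been measured. It differs from compound 1 in one place: oxan-3-yl in place of oxolan-3-yl on a carbonyl carbon. The ring of the ester substituent is widened by one carbon, and the substituent keeps its hydrogen-bond acceptor count and its lack of donors.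

Within the data shown here, of the measured steps, only the one from compound 1 to compound 2 also alters the group on the carbonyl carbon, and that step stayed within the scatter. The steps to compound 3 replace the whole ester with a 2-hydroxyethyl ether and so do not bear directly on this change. Compound 4 is therefore expected to give a number close to that of compound 1, with no step beyond the scatter, a 1.1-fold lower number from compound 1 to compound 4 (0.05 log units; within the scatter). For compound 4 the estimated value is 65000 nM, in a range of 30000 nM to 140000 nM.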

Compound 4, half-maximal inhibitory concentration: 60500 nM
For compound 4 the middle estimate is 1.1-fold (0.03 log units) above the measured one; the measured number falls inside the stated range.
By their numbers in this assay, from the lowest: compound 3; then compounds 2, 4 and 1 (each within the scatter of the next).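

In this assay, oxan-3-yl and oxolan-3-yl on the carbonyl carbon cannot be told apart, with a 1.2-fold lower number from compound 1 to compound 4 (0.08 log units; within the scatter), and the oxan-3-yl ester also cannot be told apart from the open-chain 2-ethyl-2-hydroxybutyl ester, with a 1.2-fold higher number from compound 2 to compound 4 (0.07 log units; within the scatter). The 2-hydroxyethyl ether compound 3 stands apart from this third ester as well, with a 3.3-fold higher number from compound 3 to compound 4 (0.51 log units; beyond the scatter), so all three esters shown now lie on the same side of compound 3. No measurement that could explain these results accompanies the numbers.

The compounds shown leave open whether an amine, a carboxylic acid or a phenyl ring on the carbonyl carbon would separate from compound 1. They also leave open whether the gap to compound 3 follows the 2-hydroxyethyl group or the ether link, a question that an ether with a longer chain could test.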